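From Bromo to Amino on a Side Chain

This account rests on a few compounds, and the source may have more. Where it says the series, first, only, none or still open, it means among the compounds named here.

Measured in a functional assay on HCT-8 cells (Homo sapiens) for antiproliferative activity, read by MTT assay, with a stated time of 48 h (a lower number here means a stronger inhibitor, a higher number a weaker inhibitor), so far
Compound 1 `COc1ccc(C(=O)c2ccc(OC)c3c2C=CC(C)(C)O3)c(NC(=O)CBr)c1` gives 4360 nM
Compound 2 `COc1ccc(C(=O)c2ccc3c(c2)C=CC(C)(C)O3)c(NC(=O)CBr)c1` gives 3260 nM

Compound 1 stands at 4360 nM and compound 2 stands at 3260 nM on these numbers. The two values lie within the usual scatter of each other, so neither compound ranks ahead. Compound 3 (`COc1ccc(C(=O)c2ccc(OC)c3c2C=CC(C)(C)O3)c(NC(=O)CN)c1`) keeps the core of compound 1 but carries amino in place of bromo on a saturated chain carbon bound to a carbonyl carbon. Among the compounds with values here, no measured pair shows a change of this kind, so the data offer no direct guide to its size or direction. No shift beyond the scatter is therefore expected, and the estimated step of a 1.1-fold lower number from compound 1 to compound 3 (0.04 log units; within the scatter) reflects that, with wide uncertainty. Compound 3 is expected to give about 4000 nM (estimated range 800 nM to 20000 nM).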

Compound 3, half-maximal inhibitory concentration: 1050 nM
Estimate against measurement, compound 3: 3.8-fold (0.58 log units) above; the range from low to high includes it.
By their numbers in this assay, from the lowest: compound 3; then compounds 2 and 1 (each within the scatter of the next).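

Putting amino in place of bromo on a saturated chain carbon bound to a carbonyl carbon gives, in this assay, a 4.2-fold lower number from compound 1 to compound 3 (0.62 log units; beyond the scatter), so this side chain position clearly responds to the group it carries. Compounds 1 and 2 both carry bromo there, so they could not show this, and compound 3 now shows that bromo is not required for activity in cells on the core of compound 1. No measurement at hand explains why the number falls with this change.

The compounds shown leave open whether a hydroxyl group or dimethylamino at the same place would do as well as amino or better. They also leave open whether amino brings a similar step on the core of compound 2.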